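The compounds below may be only part of what the source reports. "The series", "measured", "known", "first", "only" and "open" are said of these compounds alone.

In an ADME assay on HepG2 cells (Homo sapiens) for cytotoxicity, with a stated time of 72 h (on this read-out lower numbers stand for an effect already at smaller amounts and higher numbers for an effect only at larger amounts of compound), compound 1 `Cc1cc(NC(=O)Nc2ccc(C(C)(C)C)cc2)c2ccccc2n1` gives 17000 nM. Compound 2 `Cc1ccc(NC(=O)Nc2cc(C)nc3ccccc23)cc1` gives > 25000 nM, which is a limit and not a number. Its position is the limit of > 25000 nM in this assay, at which 1 of the 2 values shown sits. Next comes compound 3 `Cc1cc(NC(=O)Nc2cccnc2)c2ccccc2n1`, with this change: pyridin-3-yl in place of 4-methylphenyl on an amide-type nitrogen. Thus pyridin-3-yl stands in place of 4-methylphenyl on an amide-type nitrogen. For the measured compounds named here, the only measured step bearing on it is an at least 1.4-fold higher number from compound 1 to compound 2 (0.16 log units; that floor lies within the scatter), a change in the group now leaving, and it shows no size beyond the scatter. No step beyond the scatter is therefore expected, and the estimated step is a step that the limit leaves unreadable from compound 2 to compound 3. Compound 3 is expected at 30000 nM, within an estimated range of 15000 nM to 60000 nM.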

Compound 3, half-maximal effective concentration: > 25000 nM
Compound 3: no number, only a limit; the forecaster's own chance of this, stated with the estimate: 65%; the middle value lies beyond the limit too.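

No new step can be read between compound 2 and compound 3, as each gives only a limit in this assay: the limit of > 25000 nM in this assay, at which 2 of the 3 values shown sit.

On these data alone, whether pyridin-3-yl and 4-methylphenyl on an amide-type nitrogen differ at all in this assay stays open.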